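From sec-butyl to isopropyl: compound 3 to compound 4

The source may hold more compounds than are shown below. What is called first, only, known or untested is meant among the compounds shown, and "the series" means these compounds.

Compounds measured in a functional assay on HeLa cells (Homo sapiens) for cytotoxicity, read by MTT assay, with a stated time of 48 h (on this read-out higher numbers stand for weaker inhibition and lower numbers for stronger inhibition), are:
- Compound 1 `COC(=O)[C@@H](NC(=O)CSC1=CC(=O)c2cccc(OC)c2C1=O)C(C)C` gives > 100000 nM as a limit of the assay
- Compound 2 `CC[C@H](C)[C@H](NC(=O)CSC1=CC(=O)c2cccc(OC)c2C1=O)C(=O)OC` gives 94500 nM as a number
- Compound 3 `CC[C@H](C)[C@H](NC(=O)CSC1=C(OC)C(=O)c2ccccc2C1=O)C(=O)OC` gives 82000 nM as a number

Among the compounds with values here, compound 3 lies within the scatter of compound 2, and the only other value shown is a limit. Compound 4 `COC(=O)[C@@H](NC(=O)CSC1=C(OC)C(=O)c2ccccc2C1=O)C(C)C` has not yet been measured. Relative to compound 3, it carries hydrogen in place of methyl on a saturated chain carbon, three bonds along the chain from an amide-type nitrogen and a carbonyl carbon. The same difference reads sec-butyl to isopropyl. Within the data shown here, one measured step bears on this, the same exchange in the opposite direction: an at least 1.0-fold lower number from compound 1 to compound 2 (0.02 log units; that floor lies within the scatter) and this step rests on a limit. No change beyond the scatter is therefore expected in this assay and a report as a limit is also possible. The expected step is a 1.2-fold higher number from compound 3 to compound 4 (0.06 log units; within the scatter) and it is estimated to stay within the scatter. For compound 4 the estimated value is 95000 nM with an expected range from 60000 nM to 150000 nM as its span.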

Compound 4, half-maximal inhibitory concentration: 93500 nM
Compound 4: middle estimate off by 1.0-fold (0.01 log units), on the high side; the measured number falls inside the stated range.
By their numbers in this assay, from the lowest: compounds 3, 4 and 2 (each within the scatter of the next). At a limit, above all of these: compound 1.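

In this assay, the exchange of sec-butyl for isopropyl can now be read between two numbers on one core, and it stays within the scatter: a 1.1-fold higher number from compound 3 to compound 4 (0.06 log units; within the scatter). Within the data shown here, earlier, the only reading of this change rested on a limit, and it can now be set beside a step with a definite size: the same change on two cores in this assay, an at least 1.0-fold lower number (0.02 log units; that floor lies within the scatter) from compound 1 to compound 2 and a 1.1-fold lower number (0.06 log units; within the scatter) from compound 4 to compound 3; the limit leaves it open whether they differ. On the core of compound 3, the saturated chain carbon three bonds along the chain from an amide-type nitrogen and a carbonyl carbon thus carries either methyl or hydrogen with no change beyond the scatter.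

From the compounds shown here alone, the value of compound 1 is a limit, so the size of the step on its core stays open: the limit of > 100000 nM in this assay, at which 1 of the 4 values shown sits. Going by these compounds, whether a longer chain, an amine or a carboxylic acid at this carbon would move the number beyond the scatter also stays open.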